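A few compounds are considered here, and "the series" means these few. Any claim that something is new, unique, unknown or untested is made for them only; others in the source may bear on it.

Measured compounds:
Compound 1, `O=C(NNC(=O)c1cccc([N+](=O)[O-])c1)c1ccc(-n2cccc2)cc1`, in an ADME assay on A549 cells (Homo sapiens) for cytotoxicity, read by MTT assay, with a stated time of 72 h (a higher number here means a weaker inhibitor, a lower number a stronger inhibitor), gives 203000 nM.
Compound 2, `CC(=O)N1N=C(c2ccc(-n3c(C)ccc3C)cc2)OC1c1ccccc1Cl`, in this assay gives 206000 nM.
Compound 3, `O=C(NNC(=O)c1ccc([N+](=O)[O-])cc1)c1ccc(-n2cccc2)cc1`, in this assay gives 198000 nM.

The three numbers sit close together. Compound 2 has the highest of them, but its gap to compound 1 and its gap to compound 3 both lie within the usual scatter of this kind of measurement, so the three compounds cannot be told apart on these data.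

The piece follows the step from compound 2 to compound 4, `CC(=O)N1N=C(c2ccc(-n3c(C)ccc3C)cc2)OC1c1ccc(N(C)C)cc1`, which has not yet been measured in this assay. The change is 4-(dimethylamino)phenyl in place of 2-chlorophenyl on a saturated ring carbon. For the measured compounds named here, no step between measured compounds is available, so there is nothing in the data to show which way such a change moves the number, and the three measured compounds, with differing cores and substituents, all land in the same narrow range. Compound 4 is therefore expected to stay near compound 2, with an expected step of a 1.0-fold lower number from compound 2 to compound 4 (0.01 log units; within the scatter), not beyond the scatter. The expected value for compound 4 is 200000 nM, within the range 100000 nM to 400000 nM.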

Compound 4, half-maximal inhibitory concentration: 186000 nM
Compound 4: the middle estimate sits 1.1-fold (0.03 log units) above what was measured, within the range that was stated.
By their numbers in this assay, from the lowest: compounds 4, 3, 1 and 2 (each within the scatter of the next).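

For the compounds shown here, the exchange of 2-chlorophenyl for 4-(dimethylamino)phenyl on the saturated ring carbon gives the first comparison in this assay between two compounds that differ in only one place (a 1.1-fold lower number from compound 2 to compound 4 (0.04 log units; within the scatter)). Going by these compounds alone, for this pair, the change at this position leaves compound 2 and compound 4 indistinguishable, something the earlier compounds, which differ in more than one place, could not show. Nothing measured here offers an explanation for this result.

From the compounds shown here alone, it remains open whether another group on this saturated ring carbon, such as a carboxylic acid, would give a number beyond the scatter from compound 2. Also unresolved is what a propanoyl group in place of the acetyl group on the neighbouring ring atom would do.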